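Swapping a chloro for a cyclopentylcarbonylamino on compound 1

A few compounds are considered here, and "the series" means these few. Any claim that something is new, unique, unknown or untested is made for them only; others in the source may bear on it.

Measured compounds:
Compound 1, `O=C(Nc1cccc(-c2nc(-c3ccc(NC(=O)c4cccnc4)cc3Cl)no2)c1)Nc1ccc(Cl)c(C(F)(F)F)c1`: 1900 nM in a functional assay on MDA-MB-231 cells (Homo sapiens) for antiproliferative activity, read by MTT assay, with a stated time of 72 h; on this read-out lower numbers stand for stronger inhibition and higher numbers for weaker inhibition
Compound 2, `NS(=O)(=O)Nc1ccc(NC(=O)Nc2cccc(-c3nc(-c4ccc(NC(=O)c5cccnc5)cc4Cl)no3)c2)cc1`: 8900 nM

Among the two numbers so far, compound 1 stands lowest; the nearest is compound 2, with a 4.7-fold higher number from compound 1 to compound 2 (0.67 log units; beyond the scatter). That step swapped the whole aryl group on the urea nitrogen of compound 1 for one carrying a sulfamoylamino group.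

Compound 3, `O=C(Nc1cccc(-c2nc(-c3ccc(NC(=O)c4cccnc4)cc3Cl)no2)c1)Nc1ccc(NC(=O)C2CCCC2)c(C(F)(F)F)c1`, has not yet been measured. It differs from compound 1 at a single place: (cyclopentylcarbonyl)amino in place of chloro on an aromatic carbon. The trifluoromethyl group and the rest of the shared core are kept.

Within the data shown here, only one measured step exists, and it bears indirectly: it concerns a change of the same aryl group but not of the same position, and it brought a modest rise in this assay. Since the change to compound 3 adds a hydrogen-bond donor and acceptor at a different spot, a small rise or none beyond the scatter is expected, that is a 1.7-fold higher number from compound 1 to compound 3 (0.23 log units; within the scatter).

Compound 3 is therefore estimated at 3200 nM, within the range 800 nM to 13000 nM.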

Compound 3, half-maximal inhibitory concentration: 300 nM
The estimate for compound 3 lay 11-fold (1.03 log units) above the measured number, outside the stated range (below it).
By their numbers in this assay, from the lowest: compound 3; then compound 1; then compound 2.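

In this assay, this position, ortho to a trifluoromethyl group, proves able to hold far more than a single chlorine atom: a 6.3-fold lower number from compound 1 to compound 3 (0.80 log units; beyond the scatter) is a step toward stronger inhibition, beyond the scatter, and it comes with a group that brings a five-membered non-aromatic ring, one hydrogen-bond donor and one hydrogen-bond acceptor. The earlier step, a 4.7-fold higher number from compound 1 to compound 2 (0.67 log units; beyond the scatter), replaced the whole aryl group, so it could not show what this one position does by itself, whereas here the trifluoromethyl group and the rest of the molecule stay the same and the change in the number belongs to this single exchange. No measurement shown here bears on what lies behind this gain.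

The compounds shown do not separate the contribution of the amide nitrogen and its carbonyl from that of the cyclopentyl ring, since the two enter together as one group. A plain amine, an acetylamino group or a longer open chain on the carbonyl at this same place would be needed to tell those parts apart.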